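A few compounds are considered here, and "the series" means these few. Any claim that something is new, unique, unknown or untested is made for them only; others in the source may bear on it.

Measured so far in a functional assay on THP-1 cells (Homo sapiens) for inhibition, read by sulforhodamine B assay, with a stated time of 48 h; a lower number here means a stronger inhibitor, a higher number a weaker inhibitor:
compound 1 `COc1ccc(C(c2ccc(OC(C)CN(C)C)cc2)c2cccc3ccccc23)c(OC)c1OC` gives 15000 nM
compound 2 `COc1ccc(C(c2ccc(O)cc2)c2cccc3ccccc23)c(OC)c1OC` gives 9450 nM

Compound 2 holds the lower of the two numbers, but the step of a 1.6-fold lower number from compound 1 to compound 2 (0.20 log units; within the scatter) lies within the scatter, so the two compounds are not separated by this assay. Compound 3 `COc1ccc(C(c2ccc(OCC(=O)O)cc2)c2cccc3ccccc23)c(OC)c1OC` has not been measured. It differs from compound 2 by carboxymethyl in place of hydrogen on an oxygen on an aromatic ring. Among the measured compounds shown here, the only measured step touching this oxygen is a 1.6-fold lower number from compound 1 to compound 2 (0.20 log units; within the scatter), where an exchange of the group on the same oxygen for hydrogen moved the number only a little; the carboxymethyl group is a different substituent, so that step is only a loose guide. On this basis compound 3 is expected to show in this assay a shift of modest size at most, with no firm direction, a 1.1-fold higher number from compound 2 to compound 3 (0.02 log units; within the scatter). Compound 3 is therefore estimated at 10000 nM, with a range from 4000 nM to 25000 nM.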

Compound 3, half-maximal inhibitory concentration: > 20000 nM
Compound 3 ended at the assay's limit; the forecaster's own chance of this, stated with the estimate: 10%; middle value at least 2.0-fold (0.30 log units) away from the limit.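

In this assay compound 3 gives > 20000 nM, which is a limit of the assay and not a number. Among the compounds shown here, the oxygen on the aromatic ring is not indifferent to what it carries: carboxymethyl in place of hydrogen gives an at least 2.1-fold higher number from compound 2 to compound 3 (0.32 log units; beyond the scatter), the first step at this position beyond the scatter, whereas the earlier step, a 1.6-fold lower number from compound 1 to compound 2 (0.20 log units; within the scatter), separated nothing. Against compound 1 the result gives only a floor, an at least 1.3-fold higher number from compound 1 to compound 3 (0.12 log units; that floor lies within the scatter), so that pair stays unseparated.

From the compounds shown here alone, how far the number of compound 3 lies past the limit remains open, as does whether the step follows the carboxylic acid itself or the carboxymethyl chain as a whole. A methyl ester, a primary amide or a longer chain ending in a carboxylic acid on the same oxygen would bear on that question.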